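This account rests on a few compounds, and the source may have more. Where it says the series, first, only, none or still open, it means among the compounds named here.

Compounds measured so far:

Compound 1, `N#Cc1ccc(-c2csc(N/N=C\c3ccco3)n2)cc1`: in an in vitro assay on BTI-TN-5B1-4 cells for inhibition of Amine oxidase [flavin-containing] A (Homo sapiens), read by Amplex Red, with a stated time of 15 min, tested at 100 uM (on this read-out lower numbers stand for less inhibition and higher numbers for more inhibition at the one concentration tested (going by the name of the read-out)), compound 1 gives 40%.
Compound 2, `C/C(=N/Nc1nc(-c2ccc(C#N)cc2)cs1)c1ccco1`: in this assay compound 2 gives 40%.

Compound 2 stands level with compound 1 on the numbers shown; the two values agree at the digits reported, and their gap lies within the usual scatter of repeated measurements. Neither compound can therefore be said to give the higher number of the pair.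

Compound 3, `C/C(=N/Nc1nc(-c2ccc(C#N)cc2)cs1)c1cccs1`, has not yet been measured. It differs from compound 2 in one place: thiophen-2-yl in place of furan-2-yl on a carbon with a double bond to nitrogen. Going by the values given here, no step between measured compounds bears on this change, so there is nothing in the data to set its size or direction. On what is known, compound 3 is expected to give 40% in this assay, with a range from 20% to 60%. The step this estimate implies, no change at the digits printed from compound 2 to compound 3 (within the scatter), is expected to stay within the scatter.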

Compound 3, a percentage reported as inhibition, at one concentration (the size of the read-out at that concentration, not a potency): 40%
Compound 3: the middle estimate sits on the measured number at the digits printed, and the stated range covers the measured number.
By their numbers in this assay, from the lowest: compounds 1, 2 and 3 (each within the scatter of the next).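

At the carbon with a double bond to nitrogen, thiophen-2-yl in place of furan-2-yl gives no change at the digits printed from compound 2 to compound 3 (within the scatter) in this assay at the single concentration tested. Going by these compounds alone, this is the first step to bear on the ring at this position, and it shows that exchanging the ring oxygen for sulfur, with the ring size unchanged, does not separate the two compounds on this read-out. Nothing measured here accounts for the two rings reading alike.

Going by these compounds, it remains open whether a six-membered ring such as phenyl or pyridin-2-yl, or an open group such as an amine or a longer alkyl chain, would move the number beyond the scatter at this place. Also open, on these data alone, is whether the same exchange would read alike on a carbon carrying hydrogen instead of the saturated chain carbon.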